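Series notes: aromatic substituent change, compound 2 to compound 3

A few compounds are considered here, and "the series" means these few. Any claim that something is new, unique, unknown or untested is made for them only; others in the source may bear on it.

Measured so far:
compound 1 `CC1(C)Oc2ccc(C#N)cc2[C@@H](/N=C(\NC#N)Nc2ccc(Cl)cc2)[C@@H]1O` gives 1800 nM in a functional assay (aorta) with Rattus norvegicus as the target; a higher number here means a weaker inhibitor, a lower number a stronger inhibitor
compound 2 `C=C(c1ccccc1)c1ccc2c(c1)[C@@H](/N=C(\NC#N)Nc1ccc(Cl)cc1)[C@H](O)C(C)(C)O2` gives 10700 nM in this assay

Compound 2 holds the highest of the two numbers in this assay; the nearest is compound 1, and the step of a 5.9-fold higher number from compound 1 to compound 2 (0.77 log units; beyond the scatter) separates them. Compound 3 `CC1(C)Oc2ccc(S(=O)(=O)Nc3ccccc3)cc2[C@@H](/N=C(\NC#N)Nc2ccc(Cl)cc2)[C@@H]1O` differs from compound 2 by phenylsulfamoyl in place of 1-phenylethenyl on an aromatic carbon. Among the measured compounds shown here, the only measured step that bears on this place is the one from compound 1 to compound 2, where a large aromatic group in place of cyano raised the number clearly. Compound 3 again carries a large group with an aromatic ring at the same place, so a number near that of compound 2 is expected, with no confident direction; the step is estimated as a 1.3-fold lower number from compound 2 to compound 3 (0.13 log units; within the scatter). Compound 3 is expected to give 8000 nM in this assay, within the range 2000 nM to 30000 nM.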

Compound 3, half-maximal inhibitory concentration: 3300 nM
Estimate against measurement, compound 3: 2.4-fold (0.38 log units) above; the range from low to high includes it.
By their numbers in this assay, from the lowest: compounds 1 and 3 (each within the scatter of the next); then compound 2.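

In this assay, holding a six-membered aromatic ring of carbon only at this place does not by itself go with the high number of compound 2: phenylsulfamoyl in place of 1-phenylethenyl gives a 3.2-fold lower number from compound 2 to compound 3 (0.51 log units; beyond the scatter) on the otherwise shared core. Set against cyano, phenylsulfamoyl gives a 1.8-fold higher number from compound 1 to compound 3 (0.26 log units; within the scatter) and so stays within the scatter, which means that a bulkier group at this aromatic carbon need not raise the number, and that among these three compounds only 1-phenylethenyl stands apart. No measurement at hand accounts for the gap between the two ring-bearing groups.

Open, on these data alone, is whether the phenyl ring of phenylsulfamoyl matters at all, which an unsubstituted sulfamoyl or a methylsulfonyl group would test. Also open, as far as these compounds go, is how a carboxylic acid or an amine would read in this assay at this place.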